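Notes on a chain extension from compound 1 to compound 4

The source may report more compounds than this note shows. Statements on the series, on what has been measured and on what is new or still open speak of the compounds shown alone.

Three compounds have been measured in a functional assay on SGC-7901 cells (Homo sapiens) for inhibition; a higher number here means a weaker inhibitor, a lower number a stronger inhibitor:

compound 1 `CC(C)=CCC/C(C)=C/C[C@]12C[C@@H](CC=C(C)C)C(C)(C)[C@](CC=C(C)C)(C(=O)C(C(=O)c3ccc(O)c(O)c3)=C1O)C2=O` gives 5.48 ug/mL
compound 2 `CC(C)=CCC/C(C)=C/C[C@]12C(=O)CC(=O)[C@](CC=C(C)C)(C[C@@H](CC=C(C)C)C1(C)C)C2=O` gives 8.5 ug/mL
compound 3 `CC(C)=CC[C@@H]1C[C@]2(CC=C(C)C)C(=O)[C@@](CC=C(C)C)(C(=O)C(C(=O)c3ccccc3)=C2O)C1(C)C` gives 12 ug/mL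

Compound 1 holds the lowest number of the three. Compound 2 lies within the usual scatter of compound 1, so no order between those two can be read. Compound 3 lies beyond the scatter, with the higher number, so compound 3 is the weaker of that pair. Among the compounds with values here, no two measured compounds differ in one place only, so no step size is known from measurement; the three differ in several places at once, and nothing can be assigned to any single change.

Compound 4 `CC(C)=CCC/C(C)=C/C[C@@H]1C[C@]2(C/C=C(\C)CCC=C(C)C)C(=O)[C@@](CC=C(C)C)(C(=O)C(C(=O)c3ccc(O)c(O)c3)=C2O)C1(C)C` differs from compound 1 in one place: 3-methylbut-2-en-1-yl in place of hydrogen on a saturated chain carbon bound to a double-bonded chain carbon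

Nothing measured here speaks to this kind of change. Within the data shown here, with no comparable step to lean on, the expected step of a 1.2-fold higher number from compound 1 to compound 4 (0.07 log units; within the scatter) is none beyond the scatter, with the wider end of the range allowed on the weaker side. Compound 4 is estimated at 6.5 ug/mL in this assay, between 3 ug/mL and 14 ug/mL.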

Compound 4, half-maximal inhibitory concentration: 4.05 ug/mL
The estimate for compound 4 lay 1.6-fold (0.21 log units) above the measured number; the range from low to high includes it.
By their numbers in this assay, from the lowest: compounds 4, 1, 2 and 3 (each within the scatter of the next, the first and the last beyond it).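

Compound 4 gives the series its first comparison in one place: 3-methylbut-2-en-1-yl in place of hydrogen on a saturated chain carbon bound to a double-bonded chain carbon. In this assay, within the data shown here, the step reads a 1.4-fold lower number from compound 1 to compound 4 (0.13 log units; within the scatter) and so sets no order between the pair. At this place, then, 3-methylbut-2-en-1-yl can be extended to 3,7-dimethylocta-2,6-dien-1-yl with no difference that can be read from this assay. No supporting measurement bears on this result.

Open, going by these compounds, is whether an amine, a carboxylic acid or a chain longer than 3,7-dimethylocta-2,6-dien-1-yl at this place would give a step beyond the scatter. Also open, on these data alone, is whether the same extension on compound 3 would give a step of similar size.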